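This account rests on a few compounds, and the source may have more. Where it says the series, first, only, none or still open, it means among the compounds named here.

Three related compounds have so far been tested in a functional assay on MIA PaCa-2 cells (Homo sapiens) for antiproliferative activity, read by sulforhodamine B assay, with a stated time of 48 h; a higher number here means a weaker inhibitor, a lower number a stronger inhibitor. In this test compound 3 (`COc1ccc(C(=O)/C=C\Nc2ccc(-c3nc4cc(OC)c(OC)c(OC)c4s3)cc2)cc1O`) gives 32800 nM. Compound 1 (`COc1ccc(C(=O)/C=C\Nc2ccc(-c3nc4cc(OC)c(OC)c(OC)c4s3)cc2C)cc1[N+](=O)[O-]`) gives 23400 nM, which lies within the usual scatter of the number for compound 3, so the two cannot be told apart. Compound 2 (`COc1cc(OC)c2sc(-c3ccc(N/C=C\C(=O)c4ccc(OC)c([N+](=O)[O-])c4)cc3)nc2c1`) gives 2900 nM, a number lower than that of compound 3 by more than the scatter. Compound 3 therefore sits in the weaker pair of this small set, level with compound 1.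

The next compound, compound 4 (`COc1ccc(C(=O)/C=C\Nc2ccc(-c3nc4cc(OC)c(OC)c(OC)c4s3)cc2)cc1[N+](=O)[O-]`), has not yet been measured. It differs from compound 3 in one place: nitro in place of hydroxy on an aromatic carbon. Nitro takes the place of hydroxy on an aromatic carbon, ortho to a methoxy group, so 3-hydroxy-4-methoxyphenyl becomes 4-methoxy-3-nitrophenyl.

For the measured compounds named here, no pair of measured compounds shows this change on its own. The 4-methoxy-3-nitrophenyl group does already appear in compound 1, at 23400 nM, and in compound 2, at 2900 nM, so compounds carrying it reach from level with compound 3 to well below it. A modest move toward a stronger inhibitor is expected in this assay, estimated as a 2.3-fold lower number from compound 3 to compound 4 (0.37 log units; beyond the scatter). For compound 4 the estimated value is 14000 nM, with an expected range from 4500 nM to 35000 nM.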

Compound 4, half-maximal inhibitory concentration: 15900 nM
For compound 4 the middle estimate is 1.1-fold (0.06 log units) below the measured one; the range from low to high includes it.
By their numbers in this assay, from the lowest: compound 2; then compounds 4, 1 and 3 (each within the scatter of the next, the first and the last beyond it).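

In this assay, nitro in place of hydroxy on an aromatic carbon, ortho to a methoxy group, can now be read on its own: it gives a 2.1-fold lower number from compound 3 to compound 4 (0.31 log units; beyond the scatter), so at this position the nitro compound is modestly the stronger inhibitor. With the 4-methoxy-3-nitrophenyl group held constant, two further changes can also be read: methoxy in place of hydrogen gives a 5.5-fold higher number from compound 2 to compound 4 (0.74 log units; beyond the scatter) and makes compound 4 the weaker inhibitor of that pair, while hydrogen in place of methyl gives a 1.5-fold lower number from compound 1 to compound 4 (0.17 log units; within the scatter) and leaves compound 1 and compound 4 indistinguishable. No measurement offered here explains the size of any of these steps.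

Only hydroxy and nitro are shown at this position, so it remains open how an amine, a carboxylic acid or a fluorine atom would behave there. From the compounds shown here alone, it also remains open whether the step from hydroxy to nitro would keep its size on the cores of compound 1 and compound 2.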